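Fluoro on the phenyl ring: compound 4 expected

A few compounds are considered here, and "the series" means these few. Any claim that something is new, unique, unknown or untested is made for them only; others in the source may bear on it.

Compound 1 `Cc1cc(NC(=O)Cn2nnc(-c3ccccc3)n2)n(C2CCCCC2)n1` gives 96 nM in an assay on HEK293 cells for activation of Kir3.1/Kir3.2 (Homo sapiens), read by thallium flux (a lower number here means that less compound is needed, a higher number that more compound is needed for the effect), the lowest of the three numbers. Compound 2 `Cc1cc(NC(=O)Cn2nnc(-c3ccccc3)n2)n(C2CCOCC2)n1` gives 435 nM and compound 3 `CC1CC1c1cc(NC(=O)Cn2nnc(-c3ccccc3)n2)n(C2CCCCC2)n1` gives 843 nM; the steps of a 4.5-fold higher number from compound 1 to compound 2 (0.66 log units; beyond the scatter) and an 8.8-fold higher number from compound 1 to compound 3 (0.94 log units; beyond the scatter) both lie beyond the scatter. Compound 4 `Cc1cc(NC(=O)Cn2nnc(-c3ccccc3F)n2)n(C2CCCCC2)n1` differs from compound 1 by fluoro in place of hydrogen on an aromatic carbon, phenyl to 2-fluorophenyl. Neither measured step touches this ring: one swaps the group on the aromatic nitrogen of the shared core, the other the group on its aromatic carbon. For the measured compounds named here, no step therefore bears on the change, and with only fluoro entering, no shift beyond the scatter is expected, a 1.0-fold higher number from compound 1 to compound 4 (0.02 log units; within the scatter). Compound 4 is estimated at 100 nM, range 40 nM to 250 nM.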

Compound 4, half-maximal effective concentration: 187 nM
Estimate against measurement, compound 4: 1.9-fold (0.27 log units) below, and the stated range covers the measured number.
By their numbers in this assay, from the lowest: compounds 1 and 4 (each within the scatter of the next); then compounds 2 and 3 (each within the scatter of the next).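

For the compounds shown here, the phenyl ring, untouched by the earlier steps, now has a reading of its own: in this assay, a 1.9-fold higher number from compound 1 to compound 4 (0.29 log units; within the scatter) shows that fluoro on an aromatic carbon, ortho to a large group, leaves the number within the scatter of compound 1. Unlike the changes on the aromatic nitrogen and aromatic carbon of the shared core, this change gives no step beyond the scatter. Nothing available explains this result.

Open, from the compounds shown here alone, is whether chloro, methoxy or an amine in the same place would stay within the scatter. Also open, going by these compounds, is whether 2-fluorophenyl behaves the same with oxan-4-yl on the aromatic nitrogen.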